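A few compounds are considered here, and "the series" means these few. Any claim that something is new, unique, unknown or untested is made for them only; others in the source may bear on it.

Measured in a functional assay on HT-29 cells (Homo sapiens) for antiproliferative activity, read by sulforhodamine B assay, with a stated time of 48 h; on this read-out lower numbers stand for stronger inhibition and higher numbers for weaker inhibition:
- compound 1 `C/C=C(\C)C(=O)O[C@H]1C=CC(=O)O[C@H]1CCC(=O)[C@H](C)O`: 18000 nM
- compound 2 `C/C=C(\C)C(=O)O[C@H]1C=CC(=O)O[C@H]1COC(=O)[C@H](C)O`: 11000 nM

Compound 2 gives 11000 nM, and compound 1 lies within the usual scatter of it, so the two cannot be told apart. Compound 3 `C/C=C(\C)C(=O)O[C@H]1C=CC(=O)O[C@H]1CNC(=O)[C@H](C)O` has not yet been measured. It differs from compound 2 in one place: ((1-hydroxyethyl)carbonyl)amino in place of ((1-hydroxyethyl)carbonyl)oxy on a saturated chain carbon bound to a saturated ring carbon. This puts ((1-hydroxyethyl)carbonyl)amino in place of ((1-hydroxyethyl)carbonyl)oxy on a saturated chain carbon bound to a saturated ring carbon. Within the data shown here, only one measured step touches this place: a 1.6-fold lower number from compound 1 to compound 2 (0.21 log units; within the scatter). Among the measured compounds shown here, that swap of ((1-hydroxyethyl)carbonyl)methyl for ((1-hydroxyethyl)carbonyl)oxy stayed small, but no measured compound yet carries the amino link, so the evidence is thin. A change beyond the scatter in this assay is therefore not expected, and no firm direction can be given. The expected step is a 1.3-fold higher number from compound 2 to compound 3 (0.10 log units; within the scatter). Compound 3 is estimated at 14000 nM, with an expected range of 6000 nM to 32000 nM.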

Compound 3, half-maximal inhibitory concentration: 25000 nM
Estimate against measurement, compound 3: 1.8-fold (0.25 log units) below; measured number inside the range.
By their numbers in this assay, from the lowest: compounds 2, 1 and 3 (each within the scatter of the next, the first and the last beyond it).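

In this assay the change of link on a saturated chain carbon bound to a saturated ring carbon now has a measurable effect: ((1-hydroxyethyl)carbonyl)amino in place of ((1-hydroxyethyl)carbonyl)oxy gives a 2.3-fold higher number from compound 2 to compound 3 (0.36 log units; beyond the scatter) and so a modest loss of inhibition. Set against ((1-hydroxyethyl)carbonyl)methyl, the same amino group gives a 1.4-fold higher number from compound 1 to compound 3 (0.14 log units; within the scatter) and cannot be told apart from it, so only the oxy and amino forms separate, and only by a small margin. Nothing at hand accounts for this difference.

These three compounds leave open whether the effect holds beyond this single pair, since all of them keep the same (1-hydroxyethyl)carbonyl end. On these data alone, how a plain amine, a carboxylic acid or a longer chain would behave on this carbon also remains unknown.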